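The compounds below may be only part of what the source reports. "The series", "measured", "known", "first", "only" and "open" are said of these compounds alone.

In an ADME assay on microsomes from liver (Mus musculus, strain CD-1) for metabolic stability, read by LC-MS, tested at 2 uM (a higher number here means that the compound lasts longer, a lower number that the compound disappears faster), compound 1 `CN(C)S(=O)(=O)c1ccccc1Nc1cc(-c2ccc3ccn(C)c3c2)c2nccnc2c1` gives 0.233 h and compound 2 `CN(C)C(=O)c1ccncc1Nc1cc(-c2ccc3ccn(C)c3c2)c2nccnc2c1` gives 0.35 h. These two values lie within the scatter of each other, so compound 2 cannot be separated from compound 1. Compound 3 `CC(=O)N1CCC(NC(=O)c2ccncc2Nc2cc(-c3ccc4ccn(C)c4c3)c3nccnc3c2)CC1` differs from compound 2 by (1-acetylpiperidin-4-yl)amino in place of dimethylamino on a carbonyl carbon, with the change on a carbonyl carbon. Within the data shown here, no measured pair shows a comparable change, so the range stays wide. In this assay, the expected change is none beyond the scatter, with an estimated step of a 1.1-fold higher number from compound 2 to compound 3 (0.06 log units; within the scatter). The estimate for compound 3 is 0.4 h, within an expected range of 0.15 h to 1 h.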

Compound 3, half-life: 0.117 h
The estimate for compound 3 lay 3.4-fold (0.53 log units) above the measured number, outside the stated range (below it).
By their numbers in this assay, from the lowest: compounds 3, 1 and 2 (each within the scatter of the next, the first and the last beyond it).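

In this assay, among these compounds, the change from dimethylamino to (1-acetylpiperidin-4-yl)amino on a carbonyl carbon gives a 3.0-fold lower number from compound 2 to compound 3 (0.48 log units; beyond the scatter) and is the first single-place step that can be read. The substituent at this place therefore matters for the half-life, though this rests on one pair alone. No measured evidence bears on the cause of this step. Still open, as far as these compounds go, is which part of the entering group goes with the step: a plain methylamino or a piperidin-4-ylamino without the acetyl on the same carbonyl carbon would separate these parts.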